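The compounds below may be only part of what the source reports. "The series", "measured", "known", "first", "only" and "open" are said of these compounds alone.

Working notes on the series. Compound 1 `CCC(CC)n1c(-c2ccc(OCc3c(-c4c(Cl)cccc4Cl)noc3C(C)C)cc2F)nc2ccc(C(=O)O)cc21` gives 69.3 nM in an assay on isolated protein for agonist activity at Bile acid receptor (Homo sapiens), read by TR-FRET; a lower number here means that less compound is needed, a higher number that more compound is needed for the effect. Compound 2 `CC(C)c1onc(-c2c(Cl)cccc2Cl)c1COc1ccc(-c2nc3ccc(C(=O)O)cc3n2-c2ccc(F)cc2)cc1` gives 15.1 nM in this assay. Compound 3 `CC(=O)N1CCC(n2c(-c3ccc(OCc4c(-c5c(Cl)cccc5Cl)noc4C(C)C)cc3)nc3ccc(C(=O)O)cc32)CC1` was run in this assay but the entry reads "not determined" (no result reported), so compound 3 stands without a number on any scale here. Compound 4 `CCCC(CCC)n1c(-c2ccc(OCc3c(-c4c(Cl)cccc4Cl)noc3C(C)C)cc2)nc2ccc(C(=O)O)cc21` is the next member to be measured in this assay. The change from compound 3 to compound 4 is 1-propylbutyl in place of 1-acetylpiperidin-4-yl on an aromatic nitrogen. Since compound 3 has no value, the size of this step cannot be set against a starting point; compound 1, which carries a branched alkyl on the same aromatic nitrogen plus an additional fluorine, is the nearest measured neighbour and gives 69.3 nM. Compound 4 is therefore expected to land near compound 1, estimated at 45 nM with a range from 12 nM to 170 nM.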

Compound 4, half-maximal effective concentration: 30.3 nM
Compound 4: the middle estimate sits 1.5-fold (0.17 log units) above what was measured, and the stated range covers the measured number.
By their numbers in this assay, from the lowest: compounds 2 and 4 (each within the scatter of the next); then compound 1.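

Going by these compounds alone, on the aromatic nitrogen, 1-propylbutyl in place of 4-fluorophenyl gives a 2.0-fold higher number from compound 2 to compound 4 (0.30 log units; within the scatter) in this assay, the first step at this position with both ends measured. A branched open chain and a fluorinated aromatic ring on this nitrogen thus cannot be told apart here, while the step from compound 3 cannot be read. Nothing at hand bears on the reason for this result. Open, from the compounds shown here alone, is how a small chain such as methyl or a saturated carbocycle such as cyclohexyl reads on this nitrogen. Also open, going by these compounds, is whether a free piperidin-4-yl amine gives a readable number.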